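This account rests on a few compounds, and the source may have more. Where it says the series, first, only, none or still open, it means among the compounds named here.

Compound 1 `COc1ccc(C2CC(c3ccccc3)=NN2c2nc(-c3ccccc3)c(C#N)c(=O)n2C)cc1` in a functional assay on MCF7 cells (Homo sapiens) for antiproliferative activity, with a stated time of 72 h (a higher number here means a weaker inhibitor, a lower number a stronger inhibitor), gives 18000 nM. Compound 2 `COc1ccc(C2CC(c3ccc(Cl)cc3)=NN2c2nc(-c3ccccc3)c(C#N)c(=O)n2C)cc1` gives 4800 nM. Compound 3 `Cn1c(N2N=C(c3ccccc3)CC2c2ccccc2)nc(-c2ccc(Cl)cc2)c(C#N)c1=O` gives 34400 nM.

Compound 1 and compound 2 differ by one change, (chloro in place of hydrogen on an aromatic carbon), and the step between them is a 3.8-fold lower number from compound 1 to compound 2 (0.57 log units; beyond the scatter). Compound 3 rests on a different core; the difference between the two cores is not broken down here, but its value stands within the scatter of compound 1 and beyond the scatter of compound 2.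

Compound 4 `Cn1c(N2N=C(c3ccccc3)CC2c2ccc(Cl)cc2)nc(-c2ccc(Cl)cc2)c(C#N)c1=O` is not yet measured. It differs from compound 3 by chloro in place of hydrogen on an aromatic carbon, the same change as between compound 1 and compound 2. Resting on the step from compound 1 to compound 2 a 3.8-fold lower number from compound 1 to compound 2 (0.57 log units; beyond the scatter), compound 4 is expected to show a step of a 3.6-fold lower number from compound 3 to compound 4 (0.56 log units; beyond the scatter). Compound 4 is therefore estimated at 9500 nM, between 3000 nM and 30000 nM.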

Compound 4, half-maximal inhibitory concentration: 46300 nM
Estimate against measurement, compound 4: 4.9-fold (0.69 log units) below; measured number outside the range, above it.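

In this assay, the change from phenyl to 4-chlorophenyl gives a 1.3-fold higher number from compound 3 to compound 4 (0.13 log units; within the scatter), so the stronger inhibition seen on the core of compound 1 does not reappear on the core of compound 3. The change therefore cannot be assumed to carry over from one of these cores to the other, as the two steps differ by more than their scatter: the same change on two cores in this assay, a 3.8-fold lower number (0.57 log units; beyond the scatter) from compound 1 to compound 2 and a 1.3-fold higher number (0.13 log units; within the scatter) from compound 3 to compound 4, 5.0-fold (0.70 log units) apart, beyond the scatter of two such steps. For the compounds shown here, with only one pair on each core, this does not show why the steps part or how the change would behave on any further core.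

The compounds shown leave open whether bromo, an amine or a carboxylic acid in place of the chloro would follow either step. They also leave open whether the difference between the two steps would persist with such groups.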